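Replacing One Aryl Group on a Shared Core

The compounds below may be only part of what the source reports. "The series", "measured", "known", "first", "only" and "open" are said of these compounds alone.

Of the compounds shown here, three built on the same core have been tested in a functional assay, tested at 50 ug/mL; on this read-out higher numbers stand for a stronger effect at the one concentration tested and lower numbers for a weaker effect. Compound 1, `COc1cc(Br)c(C2C(C#N)=C(N)OC(c3c[nH]c4ccccc34)=C2C#N)cc1OC`, gives 18.5%. Compound 2, `N#CC1=C(N)OC(c2c[nH]c3ccccc23)=C(C#N)C1c1ccc2ccccc2c1`, is reported in this assay as "not active" (no number reported), with no number attached. Compound 3, `Cc1ccccc1C1C(C#N)=C(N)OC(c2c[nH]c3ccccc23)=C1C#N`, gives 10.4%, the lower of the two numbers available, though its gap to compound 1 lies within the usual scatter, so the two cannot be ranked against each other.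

Compound 4, `N#CC1=C(N)OC(c2c[nH]c3ccccc23)=C(C#N)C1c1ccc(F)cc1`, differs from compound 3 in one place: 4-fluorophenyl in place of 2-methylphenyl on a saturated ring carbon. Going by the values given here, no measured pair in this set makes a comparable change, so there is no step to lean on. The earlier three compounds share the rest of the structure and all sit at low or absent activity, so the expectation for compound 4 is a step of a number 1.6 percentage points higher from compound 3 to compound 4 (within the scatter) from compound 3, no larger than the scatter. Compound 4 is therefore estimated at 12%, somewhere between 0% and 28%, with a real chance that it is simply reported as not active.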

Compound 4, a percentage reported as activity, at one concentration (the size of the read-out at that concentration, not a potency): 8.4%
The estimate for compound 4 lay 3.6 percentage points above the measured number, within the range that was stated.
By their numbers in this assay, from the lowest: compounds 4, 3 and 1 (each within the scatter of the next, the first and the last beyond it).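

In this assay, the step for 4-fluorophenyl in place of 2-methylphenyl on the saturated ring carbon is a number 2 percentage points lower from compound 3 to compound 4 (within the scatter). Going by these compounds alone, this is the first one-place comparison at this position, and it shows that this particular exchange leaves compound 3 and compound 4 indistinguishable on this read-out. Because the substituent and its place on the phenyl ring both differ, this single step cannot separate the two changes, and nothing available explains why the two compounds read alike.

A 2-fluorophenyl group would separate the identity of the substituent from its place on the ring. On these data alone, it also remains open whether a more different group at this carbon, such as a carboxylic acid or an amine on the phenyl ring, would give a step beyond the scatter.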